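Thiophene amide with a nitrile in place of the acid

The compounds below may be only part of what the source reports. "The series", "measured", "known", "first", "only" and "open" are said of these compounds alone.

Measured compounds:
compound 1 `CCN(Cc1ccoc1)C(=O)COc1ccc(C)cc1`: 136 nM
compound 2 `CCN(Cc1cccs1)C(=O)COc1ccc(C(=O)O)cc1`: "not active" (no number reported)
compound 3 `CCN(Cc1ccco1)C(=O)COc1ccc(C)cc1`: 489 nM

These three compounds share one core and differ in the aryl ring attached to the amide-type nitrogen and in the substituent on the aryl ether. In an assay on HEK293 cells for agonist activity at transient receptor potential cation channel subfamily M member 8 (Homo sapiens), read by fluorescence and calcium flux, with a stated time of 15 min (a higher number here means that more compound is needed for the effect, a lower number that less compound is needed), compound 1 gives 136 nM. In this assay, within the data shown here, compound 3 gives 489 nM, and the only measured step, a 3.6-fold higher number from compound 1 to compound 3 (0.56 log units; beyond the scatter), concerns the furan attachment. In this assay compound 2 gives "not active" (no number reported), so no number stands for it: among the three it is the one for which the assay returned no value at all.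

Compound 4 `CCN(Cc1cccs1)C(=O)COc1ccc(C#N)cc1` keeps the thiophene and the core of compound 2 and differs from it only at the aryl ether: cyano in place of carboxy on an aromatic carbon. Among the measured compounds shown here, no measured step changes the group on that aromatic carbon, so the furan step between compound 1 and compound 3 gives no direct guide here; what is known is that the methyl analogue compound 1 gives 136 nM while the carboxy analogue compound 2 gives "not active" (no number reported). A cyano group is neither of these, so the size of the step cannot be read from the data, and a return to a measurable number is expected but uncertain. In this assay compound 4 is therefore expected to give about 1500 nM, with a range from 300 nM to 8000 nM.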

Compound 4, half-maximal effective concentration: 1990 nM
Beside the measured number, compound 4's estimate is 1.3-fold (0.12 log units) below it; measured number inside the range.
By their numbers in this assay, from the lowest: compound 1; then compound 3; then compound 4.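

No new step can be read from compound 4: compound 2 has no number in this assay to set against it, and compound 4 differs from compound 1 and compound 3 in more than one place. The compounds shown leave open what the thiophene and the cyano group each do on their own. Nothing shown here offers an explanation for this result.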